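The source may report more compounds than this note shows. Statements on the series, on what has been measured and on what is new or still open speak of the compounds shown alone.

Measured compounds:
compound 1 `Cc1ncc([N+](=O)[O-])n1CCOc1ccccc1` — 134 ug/mL
compound 2 `Cc1ncc([N+](=O)[O-])n1CCOc1ccc([N+](=O)[O-])cc1` — 116 ug/mL

In a functional assay on HT-29 cells (Homo sapiens) for cytotoxicity, read by MTT assay, with a stated time of 24 h (on this read-out lower numbers stand for stronger inhibition and higher numbers for weaker inhibition), compound 1 gives 134 ug/mL, and compound 2 gives 116 ug/mL. On the two numbers shown, compound 1 stands highest, but the step of a 1.2-fold lower number from compound 1 to compound 2 (0.06 log units; within the scatter) is within the scatter, so the two compounds are not separated by this assay.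

Compound 3 `Cc1ncc([N+](=O)[O-])n1CCOc1ccccc1[N+](=O)[O-]` is not yet measured. It differs from compound 1 by nitro in place of hydrogen on an aromatic carbon. Among the compounds with values here, the one measured step that bears on this change is the step from compound 1 to compound 2, also a nitro in place of hydrogen on an aromatic carbon of the same ring, though not at the same position; that step, a 1.2-fold lower number from compound 1 to compound 2 (0.06 log units; within the scatter), did not move the number beyond the scatter. Within the data shown here, no step placing a group ortho to a large group has been measured, so nothing beyond the single nitro step can be drawn on.

On that basis the step of a 1.1-fold lower number from compound 1 to compound 3 (0.05 log units; within the scatter) is expected to stay within the scatter, without a direction beyond it. For compound 3 the estimate in this assay is 120 ug/mL, with a range from 60 ug/mL to 240 ug/mL.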

Compound 3, half-maximal inhibitory concentration: 581 ug/mL
Beside the measured number, compound 3's estimate is 4.8-fold (0.68 log units) below it; the measured number lies above the stated range.
By their numbers in this assay, from the lowest: compounds 2 and 1 (each within the scatter of the next); then compound 3.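

In this assay, nitro in place of hydrogen on an aromatic carbon, ortho to a large group, gives a 4.3-fold higher number from compound 1 to compound 3 (0.64 log units; beyond the scatter) and so weakens inhibition modestly, beyond the scatter. The other nitro step on the same ring reads a 1.2-fold lower number from compound 1 to compound 2 (0.06 log units; within the scatter) and does not separate its two compounds, so among these compounds the outcome of adding a nitro differs with where the group sits, which the earlier pair alone could not show. No measurement shown accounts for this difference, and its cause remains unassigned.

Going by these compounds, whether the step belongs to nitro itself or to any group at this place stays open, and a chlorine, a methoxy group, an amine or a carboxylic acid on the same aromatic carbon would bear on that. Also open, on these data alone, is whether a longer chain in the shared core would keep the same gap between the two nitro steps.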